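Fluoro for cyano on the benzyl ring of compound 1

The compounds below may be only part of what the source reports. "The series", "measured", "known", "first", "only" and "open" are said of these compounds alone.

Compound 1 `COc1ccc(F)cc1CNCCCNc1ccnc2cc(Cc3ccc(C#N)cc3)ccc12` and compound 2 `COc1cccc(CNCCCNc2ccnc3cc(Cc4ccc(C#N)cc4)ccc23)c1O` share one core. In a physicochemical assay for solubility, with a stated time of 18 h, at pH 7.4 (a lower number here means a less soluble compound, a higher number a more soluble compound), compound 1 gives 4200 nM, and compound 2 gives 4200 nM; the step of no change at the digits printed from compound 1 to compound 2 (within the scatter) leaves compound 1 level with compound 2. Compound 3 `COc1ccc(F)cc1CNCCCNc1ccnc2cc(Cc3ccc(F)cc3)ccc12` differs from compound 1 by fluoro in place of cyano on an aromatic carbon. Among the compounds with values here, no measured step touches this position, and the single known step concerns another part of the molecule, so the change offers no direct precedent. Compound 3 is therefore expected to stay within the scatter of compound 1, with a step of a 1.2-fold lower number from compound 1 to compound 3 (0.08 log units; within the scatter), and an estimated 3500 nM between 1400 nM and 9000 nM.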

Compound 3, solubility: 4200 nM
The estimate for compound 3 lay 1.2-fold (0.08 log units) below the measured number, and the stated range covers the measured number.
By their numbers in this assay, from the lowest: compounds 1, 2 and 3 (each within the scatter of the next).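

Within the data shown here, the first step at this position reads no change at the digits printed from compound 1 to compound 3 (within the scatter) in this assay, so 4-cyanobenzyl and 4-fluorobenzyl cannot be told apart by this read-out. Together with the earlier step, this gives one step at each of two different places on the shared core, and neither lies beyond the scatter. No supporting measurement bears on this result. The compounds shown leave open whether an amine or a carboxylic acid at this aromatic carbon would hold the same level. On these data alone, a longer chain between the two amine nitrogens also remains open.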